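From 4-methylphenyl to 4-nitrophenyl in the series

The source may hold more compounds than are shown below. What is called first, only, known or untested is meant among the compounds shown, and "the series" means these compounds.

Of the compounds shown here, three on the shared core have been read so far in a functional assay on MDA-MB-231 cells (Homo sapiens) for antiproliferative activity, read by MTT assay, with a stated time of 72 h (on this read-out higher numbers stand for weaker inhibition and lower numbers for stronger inhibition), on this series. Compound 1 (`CC1=CCC2C(CC[C@@]2(C)O)C(C)(C)C1CC[C@@H]1[C@@]2(C)CC[C@@H](O)C(C)(C)O[C@@H]2CC[C@]1(C)O`) gives > 50000 nM and this is a limit of the assay. Compound 2 (`CC1=CC[C@H]2[C@H](CC[C@]2(C)O)C(C)(C)[C@@H]1CC[C@H]1[C@]2(C)CC[C@H](OC(=O)c3ccc(C)cc3)C(C)(C)O[C@H]2CC[C@@]1(C)O`) gives 33400 nM and compound 3 (`CC1=CC[C@H]2[C@@H]1CC=C(C)[C@@H](CC[C@H]1[C@]3(C)CC[C@H](OCc4ccccc4)C(C)(C)O[C@H]3CC[C@@]1(C)O)C2(C)C`) gives 35700 nM in the same test. Among the compounds with values here, these two values lie within the scatter of each other, so compound 2 stands level with the only other true number in the set.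

The next compound is compound 4 (`CC1=CC[C@H]2[C@H](CC[C@]2(C)O)C(C)(C)[C@@H]1CC[C@H]1[C@]2(C)CC[C@H](OC(=O)c3ccc([N+](=O)[O-])cc3)C(C)(C)O[C@H]2CC[C@@]1(C)O`), which carries nitro in place of methyl on an aromatic carbon, para to a large group (nitro in place of methyl on an aromatic carbon). Within the data shown here, no measured pair isolates a single change, so the expectation rests on compound 2 at 33400 nM as the anchor. The step of a 1.1-fold lower number from compound 2 to compound 4 (0.05 log units; within the scatter) is expected to stay within the scatter, with no firm direction. For compound 4 the expected value is 30000 nM with an estimated range from 13000 nM to 50000 nM in this assay when read.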

Compound 4, half-maximal inhibitory concentration: 8900 nM
Compound 4: the middle estimate sits 3.4-fold (0.53 log units) above what was measured, and the stated range ends above it.
By their numbers in this assay, from the lowest: compound 4; then compounds 2 and 3 (each within the scatter of the next). At a limit, above all of these: compound 1.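

In this assay, within the data shown here, 4-nitrophenyl in place of 4-methylphenyl gives a 3.8-fold lower number from compound 2 to compound 4 (0.57 log units; beyond the scatter), the only step that isolates a single change and one that lies beyond the scatter. Among these compounds, the aromatic carbon para to a large group therefore responds to what it carries, which the earlier compounds, none of them a single change apart, could not show. This holds for one pair only, and no measurement shown accounts for the step.

As far as these compounds go, whether the step extends to other groups on this carbon stays open, as only methyl and nitro stand there so far, and an amine, a carboxylic acid or chlorine could move the number either way. From the compounds shown here alone, whether a 4-nitrophenyl group would give a similar step on compound 3 also remains open.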